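Swapping chloro for methoxy: what to expect

The compounds below may be only part of what the source reports. "The series", "measured", "known", "first", "only" and "open" are said of these compounds alone.

Compound 1 `O=C1NCCN1c1ccc(S(=O)(=O)Nc2cccc(Br)c2)cc1`: 77 nM
Compound 2 `Cc1cccc(NS(=O)(=O)c2ccc(N3CCNC3=O)cc2)c1C`: 190 nM
Compound 3 `O=C1NCCN1c1ccc(S(=O)(=O)Nc2cccc(Cl)c2)cc1`: 55 nM

These values come from a functional assay on HT-29 cells (Homo sapiens) for antiproliferative activity, read by sulforhodamine B assay, with a stated time of 48 h; a lower number here means a stronger inhibitor, a higher number a weaker inhibitor. Compound 3 shares the low end of these numbers with one other compound: a 1.4-fold lower number from compound 1 to compound 3 (0.15 log units; within the scatter). That step exchanged one halogen for another and stayed within the scatter. The third compound lies apart, as two modest steps show: a 2.5-fold higher number from compound 1 to compound 2 (0.39 log units; beyond the scatter) and a 3.5-fold lower number from compound 2 to compound 3 (0.54 log units; beyond the scatter).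

Compound 4 `COc1cccc(NS(=O)(=O)c2ccc(N3CCNC3=O)cc2)c1` alters a single group of compound 3: methoxy in place of chloro on an aromatic carbon, meta to a large group. Going by the values given here, no measured step brings in methoxy, so the guidance is indirect. Among the compounds with values here, the only compound here without a halogen, compound 2, has the value 190 nM, which gives a slight lean towards a higher number. In this assay a step within the scatter is therefore expected, on the higher side: a 1.8-fold higher number from compound 3 to compound 4 (0.26 log units; within the scatter). The estimate for compound 4 is 100 nM, with an expected range from 30 nM to 350 nM.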

Compound 4, half-maximal inhibitory concentration: 120 nM
The estimate for compound 4 lay 1.2-fold (0.08 log units) below the measured number; the measured number falls inside the stated range.
By their numbers in this assay, from the lowest: compounds 3, 1, 4 and 2 (each within the scatter of the next, the first and the last beyond it).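

In this assay the exchange of chloro for methoxy on this aromatic carbon, meta to a large group, is a step beyond the scatter (a 2.2-fold higher number from compound 3 to compound 4 (0.34 log units; beyond the scatter)), whereas the earlier exchange of one halogen for another stayed within it. So this position does respond to the group it carries, though only modestly. Methoxy cannot be told apart from bromo here (a 1.6-fold higher number from compound 1 to compound 4 (0.19 log units; within the scatter)), and compound 4 also stays within the scatter of the dimethylphenyl compound (a 1.6-fold lower number from compound 2 to compound 4 (0.20 log units; within the scatter)), so chloro alone is separated from methoxy. Nothing available explains these differences.

Methoxy adds a hydrogen-bond acceptor that chloro lacks, and these compounds cannot show whether that matters. Also open, going by these compounds, is how this position would respond to an amine, a carboxylic acid or a longer chain such as ethoxy.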